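Replacing Phenyl with Isopropyl in Compound 1

This account rests on a few compounds, and the source may have more. Where it says the series, first, only, none or still open, it means among the compounds named here.

In a functional assay on HCT-116 cells (Homo sapiens) for inhibition, read by fluorescence, with a stated time of 48 h (a lower number here means a stronger inhibitor of growth, a higher number a weaker inhibitor of growth), compound 1 (`N[C@H](C(=O)OCCCOC1(c2ccc(Cl)cc2)c2ccccc2C(=O)N1Cc1ccccc1)c1ccccc1`) gives 43000 nM. Compound 2 (`N[C@H](C(=O)OCCCOC1(c2ccc(Cl)cc2)c2ccccc2C(=O)N1Cc1ccc(Cl)cc1)c1ccccc1`) gives 45000 nM, and compound 3 (`CC(C)[C@H](N)C(=O)OCC(C)(C)COC1(c2ccc(Cl)cc2)c2ccccc2C(=O)N1Cc1ccc(Cl)cc1`) gives 40000 nM. Compound 1 therefore lies within the scatter of both other compounds, and the three values form one tight group with no meaningful order.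

Compound 4 (`CC(C)[C@H](N)C(=O)OCCCOC1(c2ccc(Cl)cc2)c2ccccc2C(=O)N1Cc1ccccc1`) has isopropyl in place of phenyl on a saturated chain carbon bound to an amine nitrogen and a carbonyl carbon. Going by the values given here, no measured step isolates this change. Among the compounds with values here, the only step available, a 1.0-fold higher number from compound 1 to compound 2 (0.02 log units; within the scatter), concerns chloro in place of hydrogen on an aromatic carbon, so it bears on this change only indirectly. Compound 3 also carries isopropyl at that carbon, yet its value of 40000 nM stays within the scatter of compound 1.

No shift beyond the scatter is therefore expected in this assay, and the expected step is a 1.0-fold lower number from compound 1 to compound 4 (0.01 log units; within the scatter). For compound 4 the estimated value is 42000 nM, with an expected range from 25000 nM to 70000 nM.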

Compound 4, concentration for 50% growth inhibition: 65000 nM
The estimate for compound 4 lay 1.5-fold (0.19 log units) below the measured number; measured number inside the range.
By their numbers in this assay, from the lowest: compounds 3, 1, 2 and 4 (each within the scatter of the next).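

Going by these compounds alone, the comparison of compound 1 with compound 4 is the first to isolate this change, as they differ only at the saturated chain carbon bound to an amine nitrogen and a carbonyl carbon. In this assay the step is a 1.5-fold higher number from compound 1 to compound 4 (0.18 log units; within the scatter), so replacing phenyl, with its six-membered aromatic ring, by isopropyl, which has no ring, gives no shift beyond the scatter in the setting of compound 1. The data shown offer no measured explanation for this outcome.

On these data alone, whether a methyl group or a carboxylic acid at that same carbon would also stay within the scatter of compound 1 remains open. Also open, as far as these compounds go, is whether isopropyl in place of phenyl would give a similar step from compound 2, which carries the added chloro group.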